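The source may report more compounds than this note shows. Statements on the series, on what has been measured and on what is new or still open speak of the compounds shown alone.

Measured so far in a functional assay on ileum for inhibition of histamine H1 receptor (Cavia porcellus); a lower number here means a stronger inhibitor, a higher number a weaker inhibitor:
compound 1 `CCOCCn1c(N2CCN(C)CC2)nc2ccccc21` gives 10 nM.
Compound 2 `CCOCCn1c(N2CCNCC2)nc2ccccc21` gives 11 nM.
Compound 3 `CCOCCn1c(N2CCN(c3ccccc3)CC2)nc2ccccc21` gives only a limit of the assay, > 10000 nM.

Compound 1 and compound 2 sit within the scatter of each other (a 1.1-fold higher number from compound 1 to compound 2 (0.04 log units; within the scatter)), so neither can be called the stronger. Compound 3 stands at the limit of > 10000 nM in this assay, at which 1 of the 3 values shown sits, and the steps of an at least 1000-fold higher number from compound 1 to compound 3 (3.00 log units; beyond the scatter) and an at least 900-fold higher number from compound 2 to compound 3 (2.95 log units; beyond the scatter) are both large. Compound 4 `COCCCn1c(N2CCN(C)CC2)nc2ccccc21`, not yet measured, differs from compound 1 elsewhere: methoxymethyl in place of ethoxy on a saturated chain carbon, two bonds along the chain from an aromatic nitrogen. For the measured compounds named here, no measured step touches this chain; the measured steps all concern the amine nitrogen in a ring, which compound 4 keeps as in compound 1. The two structures hold the same atoms, joined differently, so the step is expected to stay within the scatter: a 1.5-fold higher number from compound 1 to compound 4 (0.18 log units; within the scatter). Compound 4 is therefore estimated at 15 nM, between 5 nM and 50 nM.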

Compound 4, half-maximal inhibitory concentration: 860 nM
For compound 4 the middle estimate is 57-fold (1.76 log units) below the measured one; measured number above the stated range.
By their numbers in this assay, from the lowest: compounds 1 and 2 (each within the scatter of the next); then compound 4. At a limit, above all of these: compound 3.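

Replacing 2-ethoxyethyl with 3-methoxypropyl keeps the same atoms, yet it gives an 86-fold higher number from compound 1 to compound 4 (1.93 log units; beyond the scatter) in this assay. For the compounds shown here, this chain, which no earlier step touched, can therefore also move the number beyond the scatter, and how its atoms are joined matters, not only which atoms it holds. Nothing measured here explains the loss. The compounds shown leave open how a longer chain such as 4-ethoxybutyl, or an amine in place of the chain's ether oxygen, would behave. They also leave open whether the same change would cost as much with hydrogen in place of methyl on the amine nitrogen in a ring.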